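Replacing trifluoromethyl with methyl in compound 3

A few compounds are considered here, and "the series" means these few. Any claim that something is new, unique, unknown or untested is made for them only; others in the source may bear on it.

Compound 1 `N#Cc1ccc(CS(=O)(=O)NC(=O)C2CCN(c3nc4c(cc3C#N)C(=O)OC4)CC2)cc1`: 8900 nM
Compound 2 `N#Cc1cc2c(nc1N1CCC(C(=O)NS(=O)(=O)Cc3ccc(F)cc3F)CC1)COC2=O`: 5200 nM
Compound 3 `N#Cc1cc2c(nc1N1CCC(C(=O)NS(=O)(=O)Cc3ccc(C(F)(F)F)cc3)CC1)COC2=O`: 15900 nM

In a functional assay (Platelet, plasma) for inhibition, with Homo sapiens as the target (on this read-out lower numbers stand for stronger inhibition and higher numbers for weaker inhibition), compound 3 stands level with compound 1 but apart from compound 2, with a 3.1-fold higher number from compound 2 to compound 3 (0.49 log units; beyond the scatter). Compound 4 `Cc1ccc(CS(=O)(=O)NC(=O)C2CCN(c3nc4c(cc3C#N)C(=O)OC4)CC2)cc1` has methyl in place of trifluoromethyl on an aromatic carbon, para to a large group (methyl in place of trifluoromethyl on an aromatic carbon). Going by the values given here, no measured compound carries methyl there. The step bearing most directly is a 1.8-fold higher number from compound 1 to compound 3 (0.25 log units; within the scatter), a change at that same aromatic carbon, while a 1.7-fold lower number from compound 1 to compound 2 (0.23 log units; within the scatter) is also small. A small move toward lower numbers is therefore expected, probably not beyond the scatter. The estimated change is a 1.6-fold lower number from compound 3 to compound 4 (0.20 log units; within the scatter). For compound 4 the estimated value is 10000 nM, with an expected range from 4500 nM to 22000 nM.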

Compound 4, half-maximal inhibitory concentration: 4280 nM
Beside the measured number, compound 4's estimate is 2.3-fold (0.37 log units) above it; measured number outside the range, below it.
By their numbers in this assay, from the lowest: compounds 4, 2, 1 and 3 (each within the scatter of the next, the first and the last beyond it).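

In this assay the aromatic carbon para to a large group now shows a change beyond the scatter: methyl in place of trifluoromethyl gives a 3.7-fold lower number from compound 3 to compound 4 (0.57 log units; beyond the scatter) and methyl in place of cyano gives a 2.1-fold lower number from compound 1 to compound 4 (0.32 log units; beyond the scatter) whereas trifluoromethyl in place of cyano had stayed within it. Setting 4-methylphenyl against the 2,4-difluorophenyl of compound 2 gives a 1.2-fold lower number from compound 2 to compound 4 (0.08 log units; within the scatter) so these two stand level. Nothing measured here gives a reason for these steps.

Going by these compounds, whether an ethyl chain, a methoxy group or an amine at that carbon would follow methyl remains open.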